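Aryl Swap on an Oxime: Expected Efficacy of Compound 3

A few compounds are considered here, and "the series" means these few. Any claim that something is new, unique, unknown or untested is made for them only; others in the source may bear on it.

Measured compounds:
compound 1, `N#Cc1cccc(/C(CCN2CCN(c3ccccn3)CC2)=N/O)c1`, gives 48% in a functional assay on HEK293 cells with D(4) dopamine receptor (Homo sapiens) as the target, read by FLIPR; on this read-out lower numbers stand for smaller maximal responses and higher numbers for larger maximal responses
compound 2, `O/N=C(\CCN1CCN(c2ccccn2)CC1)c1ccc(Cl)cc1`, gives 46% in this assay

Compound 2 has the lower of the two numbers recorded so far, but its nearest neighbour is compound 1, and the step of a number 2 percentage points lower from compound 1 to compound 2 (within the scatter) is within the usual scatter, so the two cannot be ordered. Compound 3, `Cc1ccc(O)c(/C(CCN2CCN(c3ccccn3)CC2)=N/O)c1`, has not yet been measured in this assay. It differs from compound 2 by 2-hydroxy-5-methylphenyl in place of 4-chlorophenyl on a carbon with a double bond to nitrogen.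

Going by the values given here, the one measured step that bears on this change is the replacement of the aryl group on the same carbon with a double bond to nitrogen, namely a number 2 percentage points lower from compound 1 to compound 2 (within the scatter), which left the largest response unchanged beyond the scatter. On that single precedent, the account expects the second aryl exchange to behave alike, with no step beyond the scatter in either direction. Compound 3 is therefore expected to give 46% in this assay, within an estimated range from 30% to 62%. That estimate corresponds to an expected step of no change at the digits printed from compound 2 to compound 3 (within the scatter).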

Compound 3, largest response reached (reported as efficacy), in percent of the reference or control that the assay uses: 73%
Compound 3: middle estimate off by 27 percentage points, on the low side, and the stated range ends below it.
By their numbers in this assay, from the lowest: compounds 2 and 1 (each within the scatter of the next); then compound 3.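

Once 2-hydroxy-5-methylphenyl stands on the carbon with a double bond to nitrogen, this assay shows a number 27 percentage points higher from compound 2 to compound 3 (beyond the scatter) and a number 25 percentage points higher from compound 1 to compound 3 (beyond the scatter) as well, so this position is not indifferent to the aryl group it carries. The earlier exchange, a number 2 percentage points lower from compound 1 to compound 2 (within the scatter), therefore holds only for that pair of aryl groups and not for aryl exchange here in general, and the entering group differs from 4-chlorophenyl in having 1 hydrogen-bond donor and 1 hydrogen-bond acceptor where 4-chlorophenyl has 0 of each. Nothing available accounts for the higher number of compound 3, so the link between those counts and the step remains only a coincidence of two facts.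

The hydroxy and methyl groups enter together in compound 3, so the compounds shown cannot assign the step to either one, or to the two in combination. They also leave open whether a methoxy group or an amine on the same aryl ring would keep the higher response, and whether phenyl bearing hydroxy alone would do so.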